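Exchanging a fluorinated phenyl for a pyridine on the amide

The source may hold more compounds than are shown below. What is called first, only, known or untested is meant among the compounds shown, and "the series" means these compounds.

Three compounds share a core in which an amide-type nitrogen carries a saturated chain carbon and a substituted aromatic ring. Compound 1 `Cc1cccc(F)c1N(C)C(=O)c1ccc(-c2ccc(O)cc2)o1` gives 3200 nM in an assay on cytosol from placenta for inhibition of 17-beta-hydroxysteroid dehydrogenase type 2 (Homo sapiens), read by HPLC, using microsomes, with a stated time of 10 min, in the presence of a further agent that is not named here; a higher number here means a weaker inhibitor, a lower number a stronger inhibitor. Compound 2 `Cc1ccc(F)cc1N(C)C(=O)c1ccc(-c2ccc(O)cc2)o1` gives 2200 nM in this assay, and compound 3 `Cc1c(F)cccc1N(C)C(=O)c1ccc(-c2ccc(O)cc2)o1` gives 3900 nM. Compound 3 has the highest of the three numbers, but its distance to the others is small: a 1.2-fold higher number from compound 1 to compound 3 (0.09 log units; within the scatter) and a 1.8-fold higher number from compound 2 to compound 3 (0.25 log units; within the scatter), and likewise a 1.5-fold lower number from compound 1 to compound 2 (0.16 log units; within the scatter); none of these three steps goes beyond the scatter. Compound 4 `Cc1cccnc1N(C)C(=O)c1ccc(-c2ccc(O)cc2)o1` has not yet been measured. Its change from compound 3 is 3-methylpyridin-2-yl in place of 3-fluoro-2-methylphenyl on an amide-type nitrogen. Within the data shown here, none of the measured steps touches this kind of change; all three merely exchange one fluoro-methylphenyl for another on a ring of carbon only, and all stayed within the scatter. The data therefore give no direct guide, and a ring with a nitrogen is new to this set. In this assay compound 4 is expected to give 3000 nM, with a range from 800 nM to 10000 nM. The step that this estimate means, a 1.3-fold lower number from compound 3 to compound 4 (0.11 log units; within the scatter), is expected to lie within the scatter or not far beyond it.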

Compound 4, half-maximal inhibitory concentration: > 10000 nM
Compound 4 ended at the assay's limit; the forecaster's own chance of this, stated with the estimate: 10%; middle value at least 3.3-fold (0.52 log units) away from the limit.
By their numbers in this assay, from the lowest: compounds 2, 1 and 3 (each within the scatter of the next). At a limit, above all of these: compound 4.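

The reading of compound 4 is a limit of the assay and not a number: the limit of > 10000 nM in this assay, at which 1 of the 4 values shown sits. In this assay, on these data alone, 3-methylpyridin-2-yl on the amide-type nitrogen gives an at least 2.5-fold higher number from compound 3 to compound 4 (0.40 log units; beyond the scatter), an at least 4.5-fold higher number from compound 2 to compound 4 (0.65 log units; beyond the scatter) and an at least 3.1-fold higher number from compound 1 to compound 4 (0.49 log units; beyond the scatter), so all three steps go beyond the scatter, and how far beyond stays unknown. The exchanges among compounds 1, 2 and 3, which only rearranged fluorine and methyl on a ring of carbon only, had all stayed within the scatter, so this is the first change at this position shown to weaken inhibition, and it is also the first to put a nitrogen into the ring.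

Compound 4 loses the fluorine and gains the ring nitrogen in a single step, so the compounds shown do not tell which of the two accounts for the loss. A methylphenyl ring without fluorine, a pyridine ring carrying both fluorine and methyl, or an amine in place of the methyl would each bear on that question, and none of them is among the compounds shown.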